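Nitro to fluoro on the shared core of compound 1

The source may hold more compounds than are shown below. What is called first, only, known or untested is meant among the compounds shown, and "the series" means these compounds.

Compound 1 `COc1cc(OC)c(OC)cc1/C=C/C(=O)c1ccc([N+](=O)[O-])cc1` carries a nitro group. In a functional assay on HeLa cells (Homo sapiens) for inhibition, read by MTT assay, with a stated time of 72 h (a higher number here means a weaker inhibitor, a lower number a stronger inhibitor), compound 1 gives > 150000 nM, which is a limit of the assay rather than a number (the limit of > 150000 nM in this assay, at which 1 of the 2 values shown sits). Compound 2 `COc1cc(OC)c(OC)cc1/C=C/C(=O)c1cccc([N+](=O)[O-])c1` is the other nitro isomer; in this assay compound 2 gives 130000 nM. Both values therefore lie at the weak end of what this assay reports. Compound 3 `COc1cc(OC)c(OC)cc1/C=C/C(=O)c1ccc(F)cc1` differs from compound 1 by fluoro in place of nitro on an aromatic carbon. Since only a limit is known for compound 1, no step beyond the scatter is expected, a number no higher from compound 1 to compound 3 (the limit leaves the size open). Compound 3 is accordingly estimated at 150000 nM, with a range of 60000 nM to 400000 nM, and a limit is again likely.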

Compound 3, half-maximal inhibitory concentration: 28600 nM
Compound 3: middle estimate off by 5.2-fold (0.72 log units), on the high side, and the stated range ends above it.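

In this assay, fluoro in place of nitro on this aromatic carbon gives an at least 5.2-fold lower number from compound 1 to compound 3 (0.71 log units; beyond the scatter) and so shows that this position of the shared core responds to a change of group, which the two nitro isomers alone did not show. Compound 1 gives > 150000 nM as a limit of the assay and not a number. The full size of the step therefore stays unknown: the limit of > 150000 nM in this assay, at which 1 of the 3 values shown sits.

Going by these compounds, how chloro, an amine or a carboxylic acid on the same aromatic carbon would read stays open. On these data alone, whether fluoro in place of nitro on the core of compound 2 gives a comparable step also stays open.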